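A few compounds are considered here, and "the series" means these few. Any claim that something is new, unique, unknown or untested is made for them only; others in the source may bear on it.

Measured compounds in an assay on CHO cells for displacement of a labelled ligand from adenosine receptor A3 (Homo sapiens), tested at 10 uM; a lower number here means less inhibition, a higher number more inhibition at the concentration tested (going by the name of the read-out):
- compound 1 `CC(=O)c1cc(C(=O)c2ccccc2)c(=O)[nH]c1C` gives 0%
- compound 2 `O=C(c1ccccc1)c1cc(S(=O)(=O)c2ccccc2)c(=O)[nH]c1-c1ccccc1` gives 0%
- compound 3 `O=C1CC(c2ccccc2)Cc2[nH]c(=O)c(S(=O)(=O)c3ccccc3)cc21` gives 18%

Compound 1 stands level with compound 2 at the digits read out, the two together forming the lowest pair of the three numbers; the two values lie within the usual scatter of each other, so no order between them can be read. Compound 3 lies apart from both, a number higher than compound 1 by a gap that is beyond the scatter. For the measured compounds named here, no single-point step between measured compounds is available, so the series gives no direct size for a change of the kind now considered.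

Compound 4 `CC(=O)c1cc(C(=O)C(C)(C)C)c(=O)[nH]c1C` is the unmeasured partner of compound 1. The difference between them is tert-butyl in place of phenyl on a carbonyl carbon. Nothing in the measured set shows what replacing an aromatic substituent with an open-chain one on that carbonyl carbon does to the read-out; the only reference is the flat result of compound 1 itself.

The step from compound 1 to compound 4 is therefore expected to be small, a number 3 percentage points higher from compound 1 to compound 4 (within the scatter), and not beyond the scatter in either direction. Compound 4 is estimated at 3%, with a range from -8% to 14%.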

Compound 4, a percentage reported as inhibition, at one concentration (the size of the read-out at that concentration, not a potency): 13%
Compound 4: the middle estimate sits 10 percentage points below what was measured, and the stated range covers the measured number.
By their numbers in this assay, from the lowest: compounds 1 and 2 (each within the scatter of the next); then compounds 4 and 3 (each within the scatter of the next).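

In this assay the series now has its first step in a single place: tert-butyl in place of phenyl on a carbonyl carbon gives a number 13 percentage points higher from compound 1 to compound 4 (beyond the scatter) as a modest change. The read-out at this position therefore responds to the substituent, and a group with no ring is compatible with more inhibition than the phenyl of compound 1 shows, although this remains a percentage at one concentration and not a potency. Nothing available bears on the reason for this step.

On these data alone, what an isopropyl, a cyclohexyl or an amine on that carbonyl carbon would give remains open, so the step cannot yet be assigned to tert-butyl specifically or to the loss of the phenyl ring. As far as these compounds go, it is also open whether the same change would give a similar step on the core of compound 2.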